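This account rests on a few compounds, and the source may have more. Where it says the series, first, only, none or still open, it means among the compounds named here.

Compound 1 `CNc1nc2c(N)ncnc2n1[C@@H]1O[C@H](CN(C)CCCCON)[C@@H](O)[C@H]1O` gives 49 nM in an assay on isolated protein for inhibition of S-adenosylmethionine decarboxylase proenzyme (Homo sapiens); on this read-out lower numbers stand for stronger inhibition and higher numbers for weaker inhibition; compound 2 `CN(CCCCON)C[C@H]1O[C@@H](n2cnc3c(N)ncnc32)[C@H](O)[C@@H]1O` gives 18 nM.

For the measured compounds named here, compound 2 stands at the lower of the two numbers in this assay, with compound 1 as its only neighbour; the step of a 2.7-fold lower number from compound 1 to compound 2 (0.43 log units; beyond the scatter) separates them. Compound 3 `CCc1nc2c(N)ncnc2n1[C@@H]1O[C@H](CN(C)CCCCON)[C@@H](O)[C@H]1O` differs from compound 2 by ethyl in place of hydrogen on an aromatic carbon. Going by the values given here, the one measured step that bears on this change is the one in which a substituent at this same aromatic carbon was removed, a 2.7-fold lower number from compound 1 to compound 2 (0.43 log units; beyond the scatter), so putting a group back there is expected to raise the number modestly. Compound 3 is therefore estimated at 40 nM (range 18 nM to 90 nM), a step of a 2.2-fold higher number from compound 2 to compound 3 (0.35 log units; beyond the scatter).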

Compound 3, half-maximal inhibitory concentration: 15 nM
For compound 3 the middle estimate is 2.7-fold (0.43 log units) above the measured one, outside the stated range (below it).
By their numbers in this assay, from the lowest: compounds 3 and 2 (each within the scatter of the next); then compound 1.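

Ethyl on this aromatic carbon is tolerated: the step of a 1.2-fold lower number from compound 2 to compound 3 (0.08 log units; within the scatter) shows that this group leaves the number within the scatter of the unsubstituted compound. Ethyl in place of methylamino gives a 3.3-fold lower number from compound 1 to compound 3 (0.51 log units; beyond the scatter), so among these three compounds the higher number goes with methylamino and not with every group at this carbon. Nothing available here explains why the two groups differ.

From the compounds shown here alone, whether a longer chain such as propyl, a phenyl ring or methoxy at this carbon would behave like ethyl or like methylamino remains open.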